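A few compounds are considered here, and "the series" means these few. Any claim that something is new, unique, unknown or untested is made for them only; others in the source may bear on it.

Of the compounds shown here, two sharing one core have been measured in an ADME assay for permeability, using PAMPA, at pH 7.4; on this read-out higher numbers stand for higher permeability and lower numbers for lower permeability. Compound 1 `Cc1cc(NC(=O)Nc2cccc([N+](=O)[O-])c2)c2ccccc2n1` gives 42 10^-6 cm/s in this assay, and compound 2 `COC(=O)c1cccc(NC(=O)Nc2cc(C)nc3ccccc23)c1` gives 746 10^-6 cm/s. Within the data shown here, the one step between them, an 18-fold higher number from compound 1 to compound 2 (1.25 log units; beyond the scatter), leaves compound 2 with the higher of the two numbers, and no other measured compound comes anywhere near it.

Compound 3 `COc1cccc(NC(=O)Nc2cc(C)nc3ccccc23)c1` has not yet been measured. It differs from compound 2 in one place: methoxy in place of methoxycarbonyl on an aromatic carbon. Among the measured compounds shown here, no measured step matches this change. For the measured compounds named here, the only step in hand, an 18-fold higher number from compound 1 to compound 2 (1.25 log units; beyond the scatter), replaces one group with another on an aromatic carbon, and it shows that a change at such a site can move the read-out a long way. Going by the values given here, whether the number for methoxy lies nearer that of methoxycarbonyl or that of nitro cannot be read from the two compounds measured so far, so the direction of the coming step is uncertain. The expected step is a modest one, a 1.5-fold lower number from compound 2 to compound 3 (0.17 log units; within the scatter). The estimate for compound 3 in this assay is 500 10^-6 cm/s, with a range from 150 10^-6 cm/s to 1200 10^-6 cm/s.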

Compound 3, apparent permeability: 818 10^-6 cm/s
Estimate against measurement, compound 3: 1.6-fold (0.21 log units) below; low and high end bracket the measured number.
By their numbers in this assay, from the lowest: compound 1; then compounds 2 and 3 (each within the scatter of the next).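

In this assay, the change from methoxycarbonyl to methoxy on this aromatic carbon (a 1.1-fold higher number from compound 2 to compound 3 (0.04 log units; within the scatter)) stays within the scatter, so compound 2 and compound 3 cannot be told apart. Methoxycarbonyl brings 4 heavy atoms, 2 hydrogen-bond acceptors and a double bond, while methoxy brings 2 heavy atoms, 1 hydrogen-bond acceptor and no double bond, so at this position, in this pair, these differences come with no change that can be read. Among these compounds, the second comparison (a 19-fold higher number from compound 1 to compound 3 (1.29 log units; beyond the scatter)) is large and about the same size as the step from nitro to methoxycarbonyl, which makes compound 1, with its nitro group, the one low number among the three, whereas before it was only one of two measured compounds that might have been the outlier.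

The three groups shown do not tell whether a fourth, such as an amine, a carboxylic acid or a chlorine atom, would stay with methoxy and methoxycarbonyl or fall towards nitro. Nothing at hand bears on why nitro stands apart from the other two groups.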